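The source may report more compounds than this note shows. Statements on the series, on what has been measured and on what is new or still open speak of the compounds shown alone.

Working notes on the series. Compound 1 `CCOC(=O)C1=C(C)N/C(=C/c2cc(C)n(-c3ccc(Br)cc3)c2C)C1=O` is the reference point. In a physicochemical assay for solubility, read by nephelometry, measured as kinetic solubility, at pH 2.0 (on this read-out higher numbers stand for higher solubility and lower numbers for lower solubility), compound 1 gives 2.1 ug/mL, the lowest of the two numbers recorded so far. Compound 2 `CCOC(=O)C1=C(C)N/C(=C/c2cc(C)n(-c3cc(OC)c(OC)c(OO)c3)c2C)C1=O` carries a different aryl group on the same aromatic nitrogen; in this assay compound 2 gives 6.3 ug/mL, a higher number than compound 1, and the gap between the two lies beyond the usual scatter. Within the data shown here, no step between measured compounds that differ in a single place is available, so this pair shows only that much.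

Compound 3 `CCOC(=O)C1=C(C)N/C(=C/c2cc(C)n(-c3cccnc3)c2C)C1=O` has not yet been measured. It differs from compound 1 in one place: pyridin-3-yl in place of 4-bromophenyl on an aromatic nitrogen — pyridin-3-yl in place of 4-bromophenyl on an aromatic nitrogen. Among the measured compounds shown here, no measured step of this kind exists in the set. For the measured compounds named here, the only guide is compound 2, whose change of the aryl group on the same nitrogen goes with 6.3 ug/mL in this assay. On that basis the step of a 3.8-fold higher number from compound 1 to compound 3 (0.58 log units; beyond the scatter) is expected to be an increase of moderate size, beyond the scatter. For compound 3 in this assay the expected value is 8 ug/mL, within a range from 2.5 ug/mL to 30 ug/mL.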

Compound 3, solubility: > 50 ug/mL
Compound 3: no number, only a limit (the forecaster's own chance of this, stated with the estimate: 10%); middle value at least 6.2-fold (0.79 log units) away from the limit.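

Among these compounds, this is the first single-place step, and it shows that the group on the aromatic nitrogen can by itself carry a large change in this assay: with pyridin-3-yl in place of 4-bromophenyl, the read-out gives an at least 23-fold higher number from compound 1 to compound 3 (1.37 log units; beyond the scatter). The earlier pair could not show this, since the aryl group of compound 2 is not linked to compound 1 by a single-place step, and the step now printed is large and lies beyond the usual scatter. Compound 3 reads as a limit of the assay and not as a number, so this step gives only a lower bound on the change and no exact size: the limit of > 50 ug/mL in this assay, at which 1 of the 3 values shown sits.

The step removes the bromine and brings in a ring nitrogen at once, so the compounds shown do not separate the two, and unsubstituted phenyl, pyridin-4-yl or pyridin-2-yl on the same nitrogen would be needed to tell them apart. From the compounds shown here alone, whether a basic amine such as a dimethylamino group on the phenyl ring would give a similar step at this pH also remains open.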